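Methoxy in place of chloro on compound 1

The source may hold more compounds than are shown below. What is called first, only, known or untested is meant among the compounds shown, and "the series" means these compounds.

compound 1 `Cc1cc(C)c2c(O)cc(-c3ccc(Cl)cc3)nc2n1`: 4070 nM
compound 2 `Oc1cc(-c2ccc(Cl)cc2)nc2ncccc12`: 5890 nM

Both compounds were tested in a functional assay on MDA-MB-435 cells (Homo sapiens); a lower number here means a stronger inhibitor of growth, a higher number a weaker inhibitor of growth. Compound 1 gives 4070 nM and compound 2 gives 5890 nM. These two numbers lie within the usual scatter of each other, so compound 1 stands level with compound 2, and no order can be drawn between them.

Compound 3 `COc1ccc(-c2cc(O)c3c(C)cc(C)nc3n2)cc1` has not yet been measured. It differs from compound 1 in one place, with methoxy in place of chloro on an aromatic carbon, para to a large group (methoxy in place of chloro on an aromatic carbon).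

Within the data shown here, no pair of measured compounds shows what this exchange does, so the data offer no direction for it. In this assay, a step no larger than the scatter is therefore expected, with only a loose hold on its sign. The estimated change is a 1.2-fold higher number from compound 1 to compound 3 (0.09 log units; within the scatter). Compound 3 is expected to give about 5000 nM, with an estimated range from 1800 nM to 14000 nM.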

Compound 3, concentration for 50% growth inhibition: 28800 nM
For compound 3 the middle estimate is 5.8-fold (0.76 log units) below the measured one, and the stated range ends below it.
By their numbers in this assay, from the lowest: compounds 1 and 2 (each within the scatter of the next); then compound 3.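

In this assay the exchange of chloro for methoxy on an aromatic carbon, para to a large group, gives a 7.1-fold higher number from compound 1 to compound 3 (0.85 log units; beyond the scatter) and so yields a weaker inhibitor of growth, a step beyond the scatter. Among these compounds, compound 1 and compound 2 both carry chloro at this place, so neither could speak to a change of the group there; this step is the first sign that the number responds to what stands at this carbon, and that methoxy is not an even exchange for chloro. Nothing at hand accounts for the size of the step, and this single pair offers no explanation of it.

The compounds shown hold only chloro and methoxy at this place, so it stays open whether the loss is particular to methoxy or would follow any other group there, such as fluoro, methyl, hydroxy or an amine. Going by these compounds, it also stays open whether the same exchange on compound 2, which lacks the two methyl groups of compound 1, would give a step of similar size.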